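Where compound 3 may stand after compound 2 in this test

The compounds below may be only part of what the source reports. "The series", "measured", "known", "first", "only" and "open" are said of these compounds alone.

Of the compounds shown here, two sharing one core have been tested in an ADME assay on LLC-MK2 cells (Macaca mulatta) for cytotoxicity, read by spectrophotometry and crystal violet staining, with a stated time of 4 days; on this read-out higher numbers stand for lower toxicity in this test and lower numbers for higher toxicity in this test. Compound 1 `CC(C)n1ncc2c(C(=O)Nc3ccccc3F)cc(-c3cccnc3)nc21` gives 50000 nM. Compound 2 `CC(C)n1ncc2c(C(=O)Nc3c(F)cc(F)cc3F)cc(-c3cccs3)nc21` reaches only the limit of the assay, > 200000 nM. Compound 2 therefore sits at the limit of > 200000 nM in this assay, at which 1 of the 2 values shown sits, and nothing beyond that boundary is known of it. Compound 3 `CC(C)n1ncc2c(C(=O)Nc3cc(C(N)=O)ccc3F)cc(-c3cccs3)nc21` has not yet been measured in this assay; it differs from compound 2 in a single place, namely (5-carbamoyl-2-fluorophenyl in place of 2,4,6-trifluorophenyl on an amide-type nitrogen). Among the measured compounds shown here, no pair of measured compounds that differ in one place is at hand, so the size of this change cannot be read off from what has already been tested. Since compound 2 rests at its limit, the number for compound 3 in this assay can move only modestly toward higher toxicity before it becomes a measurable figure, and a small shift in that direction, at or within the usual scatter, is the expectation here. The expected step is an at least 1.3-fold lower number from compound 2 to compound 3 (0.12 log units; that floor lies within the scatter). Compound 3 is expected to give about 150000 nM in this assay, between 40000 nM and 300000 nM.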

Compound 3, half-maximal cytotoxic concentration: 25000 nM
Beside the measured number, compound 3's estimate is 6.0-fold (0.78 log units) above it, outside the stated range (below it).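

In this assay, among the compounds shown here, putting 5-carbamoyl-2-fluorophenyl in place of 2,4,6-trifluorophenyl on an amide-type nitrogen gives an at least 8.0-fold lower number from compound 2 to compound 3 (0.90 log units; beyond the scatter), the only change at a single place that can be read so far. It shows that the number in this test depends on what this amide-type nitrogen carries, and the step, toward higher toxicity in this test, lies beyond the usual scatter. Its size is a floor and not a measured gap, because compound 2 rests at a limit of the assay: the limit of > 200000 nM in this assay, at which 1 of the 3 values shown sits.

The step joins two changes, the arrival of the carbamoyl group and the loss of fluorine, and the compounds shown do not separate them. On these data alone, whether a carboxylic acid, a nitrile or an aminomethyl group in place of the carbamoyl group would leave the number where compound 3 stands, or return it toward the limit reached by compound 2, remains open.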